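The source may hold more compounds than are shown below. What is called first, only, known or untested is meant among the compounds shown, and "the series" means these compounds.

Measured compounds in a functional assay on U2OS cells (Homo sapiens) for cytotoxicity, read by MTT assay, with a stated time of 48 h; a lower number here means a stronger inhibitor, a higher number a weaker inhibitor:
- compound 1 `COc1ccc(Nc2nc(-c3cccc(F)c3)nc3ccc(F)cc23)cc1` gives 32300 nM.
- compound 2 `Fc1cccc(-c2nc(Nc3ccccc3F)c3cc(F)ccc3n2)c1` gives > 50000 nM, a limit of the assay rather than a number.
- compound 3 `Fc1cccc(-c2nc(Nc3ccc(Cl)cc3)c3cc(F)ccc3n2)c1` gives 38400 nM.

Compound 3 carries the highest of the two numbers; its nearest neighbour is compound 1, a step of a 1.2-fold higher number from compound 1 to compound 3 (0.08 log units; within the scatter), which stays within the scatter. The value for compound 2 is a limit only (the limit of > 50000 nM in this assay, at which 1 of the 3 values shown sits), so the step of an at least 1.3-fold lower number from compound 2 to compound 3 (0.11 log units; that floor lies within the scatter) has only a floor, and an at least 1.5-fold higher number from compound 1 to compound 2 (0.18 log units; that floor lies within the scatter) likewise. All three measured steps therefore lie within the scatter, and the aryl group on the amine nitrogen has so far moved this assay by nothing that can be resolved.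

Compound 4 `Fc1cccc(-c2nc(Nc3cccc(Br)c3)c3cc(F)ccc3n2)c1` differs from compound 3 by 3-bromophenyl in place of 4-chlorophenyl on a nitrogen on an aromatic ring. Among the measured compounds shown here, the steps that bear on this change are the two swaps of the same aryl group, an at least 1.3-fold lower number from compound 2 to compound 3 (0.11 log units; that floor lies within the scatter) and a 1.2-fold higher number from compound 1 to compound 3 (0.08 log units; within the scatter), both within the scatter. The expected step of a 1.0-fold higher number from compound 3 to compound 4 (0.02 log units; within the scatter) is therefore none beyond the scatter in this assay. Compound 4 is estimated at 40000 nM, in the range 15000 nM to 100000 nM, with a fair chance that only a limit is reported.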

Compound 4, half-maximal inhibitory concentration: > 50000 nM
Compound 4: only a limit was reported; the forecaster's own chance of this, stated with the estimate: 35%; middle value at least 1.2-fold (0.09 log units) from the limit.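

In this assay compound 4 gives > 50000 nM, which is a limit of the assay and not a number: the limit of > 50000 nM in this assay, at which 2 of the 4 values shown sit.

Going by these compounds, the change from 4-chlorophenyl to 3-bromophenyl on the amine nitrogen can therefore be read only as a floor: the step of an at least 1.3-fold higher number from compound 3 to compound 4 (0.11 log units; that floor lies within the scatter) and the step of an at least 1.5-fold higher number from compound 1 to compound 4 (0.18 log units; that floor lies within the scatter) both remain open upward, and neither shows a resolved change. The step between the two compounds at the limit, compound 2 and compound 4, cannot be read. What is new is a split among the four aryl groups: the 4-methoxyphenyl and 4-chlorophenyl compounds, compound 1 and compound 3, give numbers within the scatter of each other, while the 2-fluorophenyl and 3-bromophenyl compounds, compound 2 and compound 4, reach the limit, though four compounds support this only as an observation.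

Still open, on these data alone, is whether the position of the halogen or its identity goes with reaching the limit, which a 4-bromophenyl or a 3-chlorophenyl group on the same nitrogen would separate. Also open, as far as these compounds go, is whether any aryl group on this nitrogen, such as one carrying an amine or a carboxylic acid, gives a step beyond the scatter.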